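A cyanophenyl swap on an amide-type nitrogen

The source may report more compounds than this note shows. Statements on the series, on what has been measured and on what is new or still open speak of the compounds shown alone.

In a functional assay on T98G cells (Homo sapiens) for inhibition, read by MTT assay, with a stated time of 72 h (on this read-out higher numbers stand for weaker inhibition and lower numbers for stronger inhibition), compound 1 `CC1(C)CC(NC(=S)NCc2ccccc2)c2cc(F)ccc2O1` gives 40000 nM and compound 3 `CC1(C)CC(NC(=S)Nc2ccc(C#N)cc2)c2cc(F)ccc2O1` gives 19000 nM. Compound 3 is the second highest of the three measured numbers, with compound 2 `CC1(C)CC(NC(=S)Nc2cccc(C#N)c2)c2cc(Br)ccc2O1` lowest at 9000 nM. Compound 4 `CC1(C)CC(NC(=S)Nc2cccc(C#N)c2)c2cc(F)ccc2O1`, not yet measured, differs from compound 3 by a single change, 3-cyanophenyl in place of 4-cyanophenyl on an amide-type nitrogen.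

Going by the values given here, the only measured step at this nitrogen is a 2.1-fold lower number from compound 1 to compound 3 (0.32 log units; beyond the scatter), a modest one, seen when 4-cyanophenyl replaced benzyl. It does not compare the two cyanophenyl groups directly. Compound 2 already carries the 3-cyanophenyl and gives 9000 nM, but it also differs from compound 3 elsewhere in the core, so it offers only weak guidance. A small move toward a lower number, or none beyond the scatter, is therefore expected in this assay. The expected step is a 1.4-fold lower number from compound 3 to compound 4 (0.13 log units; within the scatter). Compound 4 is estimated at 14000 nM, within an expected range of 7000 nM to 30000 nM.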

Compound 4, half-maximal inhibitory concentration: 39000 nM
Compound 4: the middle estimate sits 2.8-fold (0.44 log units) below what was measured; the whole stated range lies below it.
By their numbers in this assay, from the lowest: compound 2; then compound 3; then compounds 4 and 1 (each within the scatter of the next).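

In this assay, the change from 4-cyanophenyl to 3-cyanophenyl on the amide-type nitrogen is a 2.1-fold higher number from compound 3 to compound 4 (0.31 log units; beyond the scatter) on the fluoro core, so the two isomeric groups can be told apart here, and the step from benzyl to 4-cyanophenyl does not carry over to 3-cyanophenyl, for which the change from benzyl is a 1.0-fold lower number from compound 1 to compound 4 (0.01 log units; within the scatter) and stays within the scatter. With 3-cyanophenyl held fixed, fluoro in place of bromo on an aromatic carbon gives a 4.3-fold higher number from compound 2 to compound 4 (0.64 log units; beyond the scatter) and shows that the low number of compound 2 does not come from its 3-cyanophenyl alone. No measurement at hand explains either step.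

Going by these compounds, whether bromo has the same effect alongside 4-cyanophenyl remains open. Also open, on these data alone, is how an amine or a carboxylic acid in place of the nitrile on this phenyl would read.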